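The compounds below may be only part of what the source reports. "The series", "measured", "known", "first", "only" and "open" are said of these compounds alone.

Compound 1 `CC[C@@H](C)[C@H](NC(=O)c1ccc(C(CC)(CC)c2ccc(OCC(O)C(C)(C)C)c(C)c2)n1CC)C(=O)OC` and compound 2 `CCn1c(C(=O)Nc2cccc(C(F)(F)F)c2)ccc1C(CC)(CC)c1ccc(OCC(O)C(C)(C)C)c(C)c1` share one core and differ only at the amide. In an assay on HL-60 cells for agonist activity at vitamin D3 receptor (Homo sapiens), read by microscopy, with a stated time of 96 h (on this read-out higher numbers stand for an effect only at larger amounts of compound and lower numbers for an effect already at smaller amounts), compound 1 gives 26 nM. Compound 2, in this assay, reaches only the limit of > 50000 nM and no number. The comparison an at least 1900-fold higher number from compound 1 to compound 2 (3.28 log units; beyond the scatter) shows how strongly the group on the carbonyl governs the result, and the limit of > 50000 nM in this assay, at which 1 of the 2 values shown sits, means the true value of compound 2 may lie anywhere beyond that limit, so compound 2 stands at the weak end of what is known.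

Compound 3 `CCn1c(C(=O)OCc2ccc(F)cc2)ccc1C(CC)(CC)c1ccc(OCC(O)C(C)(C)C)c(C)c1` carries a change at the same place: (4-fluorobenzyl)oxy in place of (3-(trifluoromethyl)phenyl)amino on a carbonyl carbon. Going by the values given here, the only measured step bearing on it, from compound 1 to compound 2, is large, and it concerns a different exchange, so the direction for compound 3 is uncertain. Compound 3 is expected to improve on the limit of compound 2 by a step of an at least 10-fold lower number from compound 2 to compound 3 (1.00 log units; beyond the scatter), and its estimate in this assay is 5000 nM, ranging from 300 nM to 50000 nM.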

Compound 3, half-maximal effective concentration: > 50000 nM
Compound 3 was reported as a limit; the forecaster's own chance of this, stated with the estimate: 40%; middle value at least 10-fold (1.00 log units) from the limit.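

Compound 3 also ends at a limit of the assay and not at a number: the limit of > 50000 nM in this assay, at which 2 of the 3 values shown sit. The exchange on the carbonyl carbon thus replaces an amide with a (4-fluorobenzyl)oxy ester, losing the hydrogen-bond donor of the (3-(trifluoromethyl)phenyl)amino group, yet the step between compound 2 and compound 3 cannot be read, since both stand at the limit. What can be read is an at least 1900-fold higher number from compound 1 to compound 3 (3.28 log units; beyond the scatter), so a second, different group in place of (1-(methoxycarbonyl)-2-methylbutyl)amino also gives a large loss, and compound 1 remains the only one of the three with a measured number.

The compounds shown leave open which part of the group in compound 1 carries the result. A carboxylic acid in place of its methoxycarbonyl, or a shorter alkyl chain in place of its 2-methylbutyl part, would bear on that question.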